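The source may hold more compounds than are shown below. What is called first, only, known or untested is meant among the compounds shown, and "the series" means these compounds.

Measured compounds:
compound 1 `Cn1c(=O)c(S(=O)(=O)Cc2ccc(F)cc2F)cc2cnc(Nc3ccc4[nH]ccc4c3)nc21`, 1000 nM
compound 2 `O=c1c(S(=O)(=O)c2ccc(F)cc2F)cc2cnc(Nc3ccc4[nH]ccc4c3)nc2n1CC1CCCC1`, 10000 nM

In a functional assay on DU-145 cells (Homo sapiens) for inhibition, read by trypan blue exclusion, with a stated time of 72 h (a lower number here means a stronger inhibitor, a higher number a weaker inhibitor), compound 1 gives the lower of the two numbers, and compound 2 gives a higher number, beyond the scatter. Compound 3 `Cn1c(=O)c(S(=O)(=O)c2ccc(F)cc2N)cc2cnc(Nc3ccc4[nH]ccc4c3)nc21` is not yet measured. It differs from compound 1 by 2-amino-4-fluorophenyl in place of 2,4-difluorobenzyl on a sulfonyl sulfur. For the measured compounds named here, no measured pair shows the effect of this change alone, so the step from compound 1 is expected to be small, at most a slight weakening, a 1.5-fold higher number from compound 1 to compound 3 (0.18 log units; within the scatter). Compound 3 is therefore estimated at 1500 nM, within 400 nM to 6000 nM.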

Compound 3, half-maximal inhibitory concentration: 3000 nM
Compound 3: middle estimate off by 2.0-fold (0.30 log units), on the low side, and the stated range covers the measured number.
By their numbers in this assay, from the lowest: compound 1; then compound 3; then compound 2.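

In this assay, putting 2-amino-4-fluorophenyl in place of 2,4-difluorobenzyl on the sulfonyl sulfur brings a 3.0-fold higher number from compound 1 to compound 3 (0.48 log units; beyond the scatter). For the compounds shown here, this is the first single-place comparison at this sulfonyl sulfur, and it shows that the position responds to this change with a modest weakening, beyond the scatter. Nothing available here accounts for that weakening.

The change swaps several features at once, so the compounds shown leave open whether the weakening goes with the amine that enters or the benzyl carbon that leaves. A 2-amino-4-fluorobenzyl group on the same sulfur would separate the two.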